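Chain change on the trifluoromethyl member of the series

The source may hold more compounds than are shown below. What is called first, only, known or untested is meant among the compounds shown, and "the series" means these compounds.

In a functional assay on A549 cells (Homo sapiens) for antiproliferative activity, read by MTT assay, with a stated time of 48 h (a higher number here means a weaker inhibitor, a lower number a stronger inhibitor), compound 1 (`CCCCCCC1(O)C(=O)Nc2ccc(Nc3ccc(F)cc3)cc21`) gives 12000 nM and compound 2 (`CCCCCCC1(O)C(=O)Nc2ccc(Nc3ccc(Cl)cc3)cc21`) gives 5400 nM. Chloro in place of fluoro on an aromatic carbon is a modest step: a 2.2-fold lower number from compound 1 to compound 2 (0.35 log units; beyond the scatter). Compound 3 (`CC(C)CCC1(O)C(=O)Nc2ccc(Nc3ccc(C(F)(F)F)cc3)cc21`) gives 4200 nM, within the scatter of compound 2 and beyond the scatter of compound 1.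

Compound 4 (`CCCCCCC1(O)C(=O)Nc2ccc(Nc3ccc(C(F)(F)F)cc3)cc21`) follows from butyl in place of isopropyl on a saturated chain carbon, two bonds along the chain from a saturated ring carbon, which reads isopentyl to hexyl. For the measured compounds named here, the only measured step concerns the halogen, so no measured step tests this chain change. No step beyond the scatter is therefore expected in this assay, and the estimated step is a 1.1-fold lower number from compound 3 to compound 4 (0.02 log units; within the scatter). For compound 4 the expected value is 4000 nM, with an estimated range of 1900 nM to 8500 nM.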

Compound 4, half-maximal inhibitory concentration: 2800 nM
Compound 4: the middle estimate sits 1.4-fold (0.15 log units) above what was measured, within the range that was stated.
By their numbers in this assay, from the lowest: compounds 4, 3 and 2 (each within the scatter of the next); then compound 1.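

In this assay, butyl in place of isopropyl on this chain carbon (isopentyl to hexyl) gives a 1.5-fold lower number from compound 3 to compound 4 (0.18 log units; within the scatter), so this chain change stays within the scatter on the trifluoromethyl member. With the hexyl chain held, trifluoromethyl in place of chloro gives a 1.9-fold lower number from compound 2 to compound 4 (0.29 log units; within the scatter), also within the scatter, while trifluoromethyl in place of fluoro gives a 4.3-fold lower number from compound 1 to compound 4 (0.63 log units; beyond the scatter), which is beyond it. No measurement available here bears on the reason for the size of these steps.

Going by these compounds, the chain change rests on one pair, so whether it reads the same with chloro or fluoro on the aromatic carbon remains open. Also open, on these data alone, is how a longer chain than hexyl, or an amine or carboxylic acid at the chain end, would read at this place.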